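The compounds below may be only part of what the source reports. "The series", "measured", "known", "first", "only" and "open" are said of these compounds alone.

Within the data shown here, in an ADME assay on L929 cells (Mus musculus) for cytotoxicity, read by resazurin assay, with a stated time of 48 h (on this read-out higher numbers stand for lower toxicity in this test and lower numbers for higher toxicity in this test), compound 1 `O=c1c2cc([N+](=O)[O-])ccc2n(CCCBr)n1Cc1ccccc1` gives 25200 nM, the only actual number so far. Compound 2 `O=C(O)CCn1c2ccc([N+](=O)[O-])cc2c(=O)n1Cc1ccccc1` gives > 256000 nM, which is a limit of the assay and not a number. Compound 3 `NC(=O)CCCn1c2ccc([N+](=O)[O-])cc2c(=O)n1Cc1ccccc1` gives > 256000 nM, which is also a limit.

Compound 4 `CNC(=O)CCCn1c2ccc([N+](=O)[O-])cc2c(=O)n1Cc1ccccc1` has not yet been measured. It differs from compound 1 by one change, methylcarbamoyl in place of bromo on a saturated chain carbon, three bonds along the chain from an aromatic nitrogen.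

Among the measured compounds shown here, two measured steps bear on this change. The closer one puts carbamoyl at that same place and gives an at least 10-fold higher number from compound 1 to compound 3 (1.00 log units; beyond the scatter). The other replaces bromomethyl with carboxy and gives an at least 10-fold higher number from compound 1 to compound 2 (1.00 log units; beyond the scatter). Both lie beyond the usual scatter and point the same way, towards lower toxicity in this test.

A step of similar size and direction is therefore expected, and the estimated step is a 9.5-fold higher number from compound 1 to compound 4 (0.98 log units; beyond the scatter). For compound 4 the expected value is 240000 nM, with an estimated range from 80000 nM to 512000 nM.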

Compound 4, concentration lethal to 50% of the cells: > 256000 nM
Compound 4 was reported as a limit (the forecaster's own chance of this, stated with the estimate: 65%); middle value at least 1.0-fold (0.02 log units) from the limit.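

In this assay, putting methylcarbamoyl in place of bromo gives an at least 10-fold higher number from compound 1 to compound 4 (1.00 log units; beyond the scatter). Compound 4 thus joins compound 2 and compound 3, so all of the non-bromo chain ends shown reach the limit of the test, and compound 1 remains the only compound with an actual number. The steps among compound 2, compound 3 and compound 4 cannot be read, and the methyl on the amide nitrogen shows no effect that can be sized, because all three values are limits: the limit of > 256000 nM in this assay, at which 3 of the 4 values shown sit.

Going by these compounds, it remains open whether a chloro or hydroxy group on the same chain carbon, or a plain propyl chain, would give a real number like compound 1 or also reach the limit. An amine at that place, or a longer chain carrying the methylcarbamoyl group, is equally untested among the compounds shown.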